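This account rests on a few compounds, and the source may have more. Where it says the series, first, only, none or still open, it means among the compounds named here.

In an ADME assay on HaCaT cells (Homo sapiens) for cytotoxicity, read by MTT assay, with a stated time of 72 h (a higher number here means a weaker inhibitor, a lower number a stronger inhibitor), three compounds have been measured:

- compound 1 `CCCCNC1=CC(=O)C=C(C(C)(C)C)C1=O` gives 11000 nM
- compound 2 `CC(C)(C)C1=CC(=O)C=C(NCc2ccccc2)C1=O` gives 21000 nM
- compound 3 `CC(C)(C)C1=CC(=O)C(NCc2ccccc2)=CC1=O` gives 28000 nM

The number for compound 3 lies within the scatter of compound 2 and clearly above compound 1. Compound 4 `CCCCNC1=CC(=O)C(C(C)(C)C)=CC1=O` is compound 3 with propyl in place of phenyl on a saturated chain carbon bound to an amine nitrogen. Going by the values given here, one measured step bears on this: the reverse swap, made on a different parent (a 1.9-fold higher number from compound 1 to compound 2 (0.28 log units; within the scatter)). Run backwards, it suggests a modestly lower number, but nothing beyond the scatter is expected (a 1.9-fold lower number from compound 3 to compound 4 (0.27 log units; within the scatter)). In this assay the estimate for compound 4 is an expected value of 15000 nM (range 8000 nM to 28000 nM).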

Compound 4, half-maximal inhibitory concentration: > 100000 nM
Compound 4: only a limit was reported (the forecaster's own chance of this, stated with the estimate: 5%); at least 6.6-fold (0.82 log units) between middle value and limit.
By their numbers in this assay, from the lowest: compounds 1, 2 and 3 (each within the scatter of the next, the first and the last beyond it). At a limit, above all of these: compound 4.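

In this assay, going by these compounds alone, propyl in place of phenyl on a saturated chain carbon bound to an amine nitrogen raises the number on this core (an at least 3.5-fold higher number from compound 3 to compound 4 (0.55 log units; beyond the scatter)), a clear change that the earlier compounds did not show. On these data alone, compound 4 gives only a limit, so its true number is unknown. The swap therefore does not carry over from one core to the other: the same change on two cores in this assay, a 1.9-fold higher number (0.28 log units; within the scatter) from compound 1 to compound 2 and an at least 3.5-fold lower number (0.55 log units; beyond the scatter) from compound 4 to compound 3, at least 6.8-fold (0.83 log units) apart, beyond the scatter of two such steps

As far as these compounds go, how a longer chain, or a chain ending in an amine or a carboxylic acid, would behave in this place on either core stays open.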